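The compounds below may be only part of what the source reports. "The series", "measured", "known", "first", "only" and "open" are said of these compounds alone.

Compound 1 `CCCCCCCCc1ccc(OCC(=O)Cn2nnc(-c3ccc(C(=O)OC)cc3)n2)cc1`: 64%
Compound 2 `CCCCCCCCc1ccc(OCC(=O)Cn2nnc(C(=O)OC)n2)cc1`: < 5% (a limit)

Going by the values given here, in an ADME assay on S9 fraction from liver (Rattus norvegicus) for metabolic stability, read by LC-MS, using NADPH, with a stated time of 30 min (on this read-out lower numbers stand for a less stable compound and higher numbers for a more stable compound), compound 1 gives 64%, the only actual number available. Compound 2 gives < 5%, which is a limit of the assay. Compound 3 `CCCCCCCCc1ccc(OC(C)C(=O)Cn2nnc(-c3ccc(C(=O)OC)cc3)n2)cc1` differs from compound 1 by methyl in place of hydrogen on a saturated chain carbon bound to a carbonyl carbon and an oxygen on an aromatic ring. Among the compounds with values here, the one measured step, a number at least 59 percentage points lower from compound 1 to compound 2 (beyond the scatter), is large but concerns a different change at another place, so it gives little guide to the size of this one. In this assay the expected outcome is a small step, not beyond the scatter, estimated as no change at the digits printed from compound 1 to compound 3 (within the scatter). For compound 3 the estimated value is 64%, with an expected range from 42% to 82%.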

Compound 3, percent of the compound remaining: 62%
Beside the measured number, compound 3's estimate is 2 percentage points above it; low and high end bracket the measured number.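

In this assay, methyl in place of hydrogen on a saturated chain carbon bound to a carbonyl carbon and an oxygen on an aromatic ring gives a number 2 percentage points lower from compound 1 to compound 3 (within the scatter). This position therefore tolerates methyl in this read-out, which the earlier step, made at another place, could not show. Nothing available here explains this result. As far as these compounds go, whether an ethyl, a hydroxyl or an amine on the same carbon would also stay within the scatter remains open. So does whether methyl there would behave the same way on the core of compound 2.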